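Chloro in Place of Fluoro on Compound 3

A few compounds are considered here, and "the series" means these few. Any claim that something is new, unique, unknown or untested is made for them only; others in the source may bear on it.

In an ADME assay on the whole organism (Mus musculus, strain CD1) for pharmacokinetics, read by LC-MS, with a stated time of 24 h, at a dose of 1 mg/kg by the intravenous route (on this read-out lower numbers stand for narrower distribution and higher numbers for wider distribution into tissues), compound 1 (`O=C(O)Cn1nc(Cc2nc3cc(Cl)c(OCC(F)F)cc3[nH]2)c2ccccc2c1=O`) gives 1.2 L/kg and compound 2 (`CCOc1cc2[nH]c(Cc3nn(CC(=O)O)c(=O)c4ccccc34)nc2cc1Cl`) gives 0.5 L/kg as the two chloro compounds. Compound 3 (`O=C(O)Cn1nc(Cc2nc3cc(F)c(OCC4CC4)cc3[nH]2)c2ccccc2c1=O`), which carries fluoro, gives 0.7 L/kg and so stands in the middle of the three numbers, within the scatter of both others. Compound 4 (`O=C(O)Cn1nc(Cc2nc3cc(Cl)c(OCC4CC4)cc3[nH]2)c2ccccc2c1=O`) follows from compound 3 with chloro in place of fluoro on an aromatic carbon, ortho to a cyclopropylmethoxy group. For the measured compounds named here, the one measured step is a 2.4-fold lower number from compound 1 to compound 2 (0.38 log units; beyond the scatter) with methyl in place of difluoromethyl on the chain. Going by the values given here, that step leaves the chloro untouched, so it bears only loosely on this swap, and no measured pair compares fluoro with chloro directly. No step beyond the scatter is therefore expected in this assay for this change. The expected step is a 1.1-fold higher number from compound 3 to compound 4 (0.06 log units; within the scatter) and stays within the scatter. For compound 4 the estimate is 0.8 L/kg and the range from 0.45 L/kg to 1.4 L/kg is what repeated measurements are expected to span.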

Compound 4, volume of distribution at steady state in the Mus musculus assay: 1 L/kg
Beside the measured number, compound 4's estimate is 1.3-fold (0.10 log units) below it; the range from low to high includes it.
By their numbers in the Mus musculus assay, from the lowest: compounds 2, 3, 4 and 1 (each within the scatter of the next, the first and the last beyond it).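

In the Mus musculus assay the swap at this aromatic carbon, ortho to a cyclopropylmethoxy group, now has a direct reading, a 1.4-fold higher number from compound 3 to compound 4 (0.15 log units; within the scatter), so fluoro and chloro are not separated on this read-out. With chloro held in the Mus musculus assay, cyclopropyl in place of methyl gives a 2.0-fold higher number from compound 2 to compound 4 (0.30 log units; within the scatter) and cyclopropyl in place of difluoromethyl gives a 1.2-fold lower number from compound 1 to compound 4 (0.08 log units; within the scatter), so neither chain change stands clear of the scatter. The same swap does register in a physicochemical assay for solubility, measured as thermodynamic solubility, at pH 7.4 (a lower number here means a less soluble compound, a higher number a more soluble compound), where compound 3 gives 841 ug/mL and compound 4 gives 395 ug/mL, as a modest loss of solubility: the measured solubility of compound 3, 841 ug/mL, and of compound 4, 395 ug/mL, a 2.1-fold lower number (0.33 log units; beyond the scatter)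

As far as these compounds go, this is a single fluoro and chloro pair, so whether the loss in the physicochemical assay also holds with methyl or difluoromethyl on the chain remains open. From the compounds shown here alone, how a nitrile or an amine on this aromatic carbon would read in either assay also remains open.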